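This account rests on a few compounds, and the source may have more. Where it says the series, first, only, none or still open, it means among the compounds named here.

Measured in a functional assay on ECa-109 cells for inhibition, with ECa-109 cell line (Homo sapiens) as the target, read by sulforhodamine B assay; on this read-out lower numbers stand for stronger inhibition and higher numbers for weaker inhibition:
- compound 1 `Cc1ccc(NC2=CC(=O)c3c(nc4n3[C@H]3OC[C@@H](O)[C@H]3OC4)C2=O)cc1C`: 4090 nM
- compound 2 `O=C1C=C(NC2CCCCC2)C(=O)c2c1nc1n2[C@H]2OC[C@@H](O)[C@H]2OC1`: > 16000 nM (a limit of the assay, not a number)
- compound 3 `Cc1ccc(NC2=CC(=O)c3nc4n(c3C2=O)[C@H]2OC[C@@H](O)[C@H]2OC4)cc1`: 3480 nM

Only two of these results are true numbers. Compound 1 at 4090 nM lies within the scatter of compound 3 at 3480 nM, so the two cannot be ranked.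

Compound 4 `COc1cccc(NC2=CC(=O)c3c(nc4n3[C@H]3OC[C@@H](O)[C@H]3OC4)C2=O)c1` starts from compound 1 and carries 3-methoxyphenyl in place of 3,4-dimethylphenyl on an amine nitrogen. One six-membered aromatic ring of carbon thus leaves and another enters.

Among the compounds with values here, only one measured step is available for comparison: an at least 4.5-fold lower number from compound 2 to compound 3 (0.66 log units; beyond the scatter). It starts from compound 2, so its size rests on (the limit of > 16000 nM in this assay, at which 1 of the 3 values shown sits). That step exchanges cyclohexyl for an aromatic group, whereas the change to compound 4 swaps one aromatic group for another, so it bears only loosely. Within the data shown here, no measured step exchanges one aromatic group for another on this nitrogen. The closest guide is therefore the value of compound 1 itself, 4090 nM, and no shift beyond the scatter, in either direction, is expected in this assay.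

The expected change is a 1.0-fold lower number from compound 1 to compound 4 (0.01 log units; within the scatter). For compound 4 the estimate is 4000 nM, with an expected range from 1600 nM to 12000 nM.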

Compound 4, half-maximal inhibitory concentration: 3340 nM
Beside the measured number, compound 4's estimate is 1.2-fold (0.08 log units) above it; the range from low to high includes it.
By their numbers in this assay, from the lowest: compounds 4, 3 and 1 (each within the scatter of the next). At a limit, above all of these: compound 2.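

In this assay, exchanging one aromatic group for another on the amine nitrogen gives a 1.2-fold lower number from compound 1 to compound 4 (0.09 log units; within the scatter), so the two compounds cannot be ranked. The earlier step set cyclohexyl against an aromatic group, whereas this pair compares two aromatic groups on the same core, with the ring itself kept and only its substituents changed. Here, 3-methoxyphenyl, which brings a hydrogen-bond acceptor that 3,4-dimethylphenyl lacks, serves as well as 3,4-dimethylphenyl in this assay, and nothing measured here gives a reason for that.

This is a single pair, so it does not show that other substituents on the ring would be tolerated in the same way. Going by these compounds, whether a phenyl ring carrying a chlorine, an amine or a carboxylic acid, or a pyridine ring in place of the phenyl ring, would shift the number beyond the scatter remains open.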